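Aryl swap at the ring nitrogen: compound 2 to compound 3

A few compounds are considered here, and "the series" means these few. Any claim that something is new, unique, unknown or untested is made for them only; others in the source may bear on it.

Of the compounds shown here, two have been measured in an ADME assay on RAW264.7 cells (Mus musculus) for cytotoxicity, read by MTT assay, with a stated time of 48 h, tested at 50 uM; a lower number here means less inhibition, a higher number more inhibition at the concentration tested (going by the name of the read-out). Compound 1 `N=C1S/C(=C\c2ccc(OCc3ccccc3)cc2)C(=O)N1c1ccc(Br)cc1` gives 7.83%. Compound 2 `Cc1c(Cl)cccc1N1C(=N)S/C(=C\c2ccc(OCc3ccccc3)cc2)C1=O` gives 59.7%. Going by the values given here, the single step between them, a number 51.9 percentage points higher from compound 1 to compound 2 (beyond the scatter), is the only measured change at the ring nitrogen so far. Compound 2 therefore stands highest of the two numbers in this assay, with compound 1 as its nearest neighbour well beyond the scatter.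

Compound 3 `Cc1ccc(C)c(N2C(=N)S/C(=C\c3ccc(OCc4ccccc4)cc3)C2=O)c1` is not yet measured. It differs from compound 2 by 2,5-dimethylphenyl in place of 3-chloro-2-methylphenyl on an amide-type nitrogen in a ring. Among the compounds with values here, no measured step covers this particular exchange; the one step that bears on it is a number 51.9 percentage points higher from compound 1 to compound 2 (beyond the scatter), which shows that changing the aryl group on this nitrogen can move the read-out by a large amount. Within the data shown here, with only that step to go on, the direction of the present change is uncertain, and a moderate fall from compound 2 is expected rather than another large shift.

For compound 3 a value of 45% is estimated in this assay, with a range from 12% to 68%. This estimate corresponds to an expected step of a number 14.7 percentage points lower from compound 2 to compound 3 (beyond the scatter).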

Compound 3, a percentage reported as inhibition, at one concentration (the size of the read-out at that concentration, not a potency): 45.8%
For compound 3 the middle estimate is 0.8 percentage points below the measured one; the range from low to high includes it.
By their numbers in this assay, from the lowest: compound 1; then compound 3; then compound 2.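

Notes on the aryl group on the amide-type nitrogen in a ring: in this assay, a second exchange among aryl groups of equal heavy-atom count gives a number 13.9 percentage points lower from compound 2 to compound 3 (beyond the scatter), so replacing 3-chloro-2-methylphenyl with the all-carbon 2,5-dimethylphenyl still moves the read-out beyond the scatter, though only modestly. The other new step, a number 38 percentage points higher from compound 1 to compound 3 (beyond the scatter), is large and places both methyl-bearing aryl groups well above 4-bromophenyl, a pattern that holds across these three compounds with none against it, and that a single pair could not show. No available evidence gives a reason for either step.

The three aryl groups differ in more than one feature, so the compounds shown leave open whether the low value of compound 1 goes with the bromine itself or with the lack of a methyl group on the ring. Also open, as far as these compounds go, is how far the read-out would move with plain 2-methylphenyl on this nitrogen, or with an aryl group carrying an amine or a carboxylic acid.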